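The source may report more compounds than this note shows. Statements on the series, on what has been measured and on what is new or still open speak of the compounds shown alone.

Compound 3 `CCOC(=O)CCCCCOc1cccc(CN(C(=O)c2ccc(-c3cccc(OCC)c3)cc2)C(C)C)c1` is one of three compounds whose measurements in an ADME assay on Raji cells (Homo sapiens) for cytotoxicity, read by CellTiter-Glo and resazurin assay, with a stated time of 72 h (a lower number here means that less compound is needed, a higher number that more compound is needed for the effect), all end at a limit, so it stands level with the others rather than above or below them. In this assay compound 3 gives > 22300 nM, which is a limit and not a number. Compound 1 `CC(C)N(Cc1cccc(OCCCCCC(=O)O)c1)C(=O)c1ccc(-c2ccc3c(c2)OCCO3)cc1` gives > 21900 nM in this assay, again a limit. Compound 2 `CCOC(=O)CCCCCOc1cccc(CN(C(=O)c2ccc(-c3ccc4ccccc4c3)cc2)C(C)C)c1` gives only the limit > 26000 nM in this assay. Among the compounds with values here, the single measured step, a step that the two limits leave unreadable from compound 2 to compound 3, is a change on the same aromatic carbon, but both of its ends are limits (the limit of > 26000 nM in this assay, at which 1 of the 3 values shown sits, and (the limit of > 22300 nM in this assay, at which 1 of the 3 values shown sits)), so its size cannot be read.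

Compound 4 `CCOC(=O)CCCCCOc1cccc(CN(C(=O)c2ccc(-c3ccc4c(c3)OCCO4)cc2)C(C)C)c1` differs from compound 3 by 2,3-dihydro-1,4-benzodioxin-6-yl in place of 3-ethoxyphenyl on an aromatic carbon. Within the data shown here, the group that enters is the one already carried by compound 1, which sits at the limit of > 21900 nM in this assay, at which 1 of the 3 values shown sits. With every value at hand being a limit, no step beyond the scatter is expected, and the result for compound 4 is expected again to be a limit rather than a number. The step from compound 3 to compound 4 is estimated as a step that the limit leaves unreadable from compound 3 to compound 4. Compound 4 is therefore estimated at 30000 nM, within a range from 15000 nM to 100000 nM.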

Compound 4, half-maximal effective concentration: > 24400 nM
Compound 4: a limit, no number; the forecaster's own chance of this, stated with the estimate: 85%; the middle value does not contradict the limit.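

Compound 4 also ends at a limit in this assay, so its steps from compound 1, compound 2 and compound 3 cannot be read. The compounds shown leave open at what concentration any of them reaches the half-maximal effect, and whether the exchanged groups change it.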